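Series notes: side-chain exchange on the pyridine core, single-concentration inhibition

The source may report more compounds than this note shows. Statements on the series, on what has been measured and on what is new or still open speak of the compounds shown alone.

Measured compounds:
compound 1, `CNC(=O)CCc1ccncc1-c1ccc2ccccc2c1` — 100%
compound 2, `CN1CCN(C(=O)/C=C/c2ccncc2-c2ccc(F)cc2)CC1` — 84%

In an assay on a protein complex for inhibition of CDK8/Cyclin C (Homo sapiens), with a stated time of 1 h, tested at 10 uM (a higher number here means more inhibition at the concentration tested (going by the name of the read-out), a lower number less inhibition), compound 1 gives 100%, the highest of the two numbers available. Compound 2 gives 84% in this assay, and its number lies below that of compound 1 by a gap beyond the usual scatter. Among the compounds with values here, no pair of measured compounds differs in one place only, so no single structural step has yet been sized.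

Compound 3, `COC(=O)COc1ccncc1-c1ccc2ccccc2c1`, is the next compound for this assay. It keeps the core and the naphthyl group of compound 1 and differs from it as follows: (methoxycarbonyl)methoxy in place of 2-(methylcarbamoyl)ethyl on an aromatic carbon. Within the data shown here, nothing among the measured compounds samples this exchange, and the bearing of the 2-(methylcarbamoyl)ethyl chain on the read-out is unknown.

Compound 1 sits at the top of the read-out, so a step from it can only go down or stay level. The step of a number 14 percentage points lower from compound 1 to compound 3 (beyond the scatter) is expected to be small, perhaps within the scatter. For compound 3 the estimate is 86%, with a range from 55% to 100%.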

Compound 3, a percentage reported as inhibition, at one concentration (the size of the read-out at that concentration, not a potency): 11%
Compound 3: middle estimate off by 75 percentage points, on the high side; measured number below the stated range.
By their numbers in this assay, from the lowest: compound 3; then compound 2; then compound 1.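

In this assay, placing (methoxycarbonyl)methoxy in place of 2-(methylcarbamoyl)ethyl on the aromatic carbon opposite the ring nitrogen gives a number 89 percentage points lower from compound 1 to compound 3 (beyond the scatter), the first step sized in this series. With the core and the naphthyl group held constant, the read-out therefore depends strongly on the group at this position, even though both groups have 6 heavy atoms and no ring. The exchange alters more than one feature at once, including the atom attached to the ring, the replacement of the amide by an ester, and the change from 1 hydrogen-bond donor to 0 hydrogen-bond donors, and no measurement available here ties the loss to any one of these.

The compounds shown do not separate the ether oxygen attached to the ring from the ester at the end of the chain: a (methylcarbamoyl)methoxy group would keep the amide with the oxygen link, whereas a 2-(methoxycarbonyl)ethyl group would keep the all-carbon link with the ester. Also open, on these data alone, is how a carboxylic acid, a tertiary amide or a longer chain at this position would read out on the same core.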